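The source may hold more compounds than are shown below. What is called first, only, known or untested is meant among the compounds shown, and "the series" means these compounds.

Measured so far in a functional assay on CHO-K1 cells for antagonist activity at transient receptor potential cation channel subfamily V member 1 (Homo sapiens), read by FLIPR; on this read-out lower numbers stand for stronger inhibition and higher numbers for weaker inhibition:

- compound 1, `CC(C(=O)NCc1ccc(C(F)(F)F)nc1NCc1ccccc1)c1ccc(NS(C)(=O)=O)c(F)c1`: 15.8 nM
- compound 2, `CC(C(=O)NCc1ccc(C(F)(F)F)nc1N1CCCCC1C)c1ccc(NS(C)(=O)=O)c(F)c1`: 2.9 nM
- compound 3, `CC(C(=O)NCc1ccc(C(F)(F)F)nc1N1CCN(C)CC1)c1ccc(NS(C)(=O)=O)c(F)c1`: 146 nM

Compound 3 gives the highest number of the three in this assay. The two steps that lead to it are a 9.2-fold higher number from compound 1 to compound 3 (0.97 log units; beyond the scatter) and a 50-fold higher number from compound 2 to compound 3 (1.70 log units; beyond the scatter); the remaining step, a 5.4-fold lower number from compound 1 to compound 2 (0.74 log units; beyond the scatter), runs the other way. All three measured steps exchange the whole group on the aromatic carbon.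

Compound 4, `CC(C(=O)NCc1ccc(C(F)(F)F)nc1N1CCN(C2CCCCC2)CC1)c1ccc(NS(C)(=O)=O)c(F)c1`, keeps the group of compound 3 and alters only its ring substituent: cyclohexyl in place of methyl on an amine nitrogen in a ring. Among the measured compounds shown here, no measured step touches the substituent on that ring nitrogen, so none bears on it directly. What the series does show is that compound 3 sits far from compound 2 and a good way from compound 1, which leaves room on the stronger side. The step is expected to be modest and downward, a 2.9-fold lower number from compound 3 to compound 4 (0.47 log units; beyond the scatter), with wide uncertainty. For compound 4 the estimate in this assay is 50 nM, with a range from 12 nM to 200 nM.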

Compound 4, inhibition constant: 21.6 nM
Compound 4: middle estimate off by 2.3-fold (0.36 log units), on the high side, within the range that was stated.
By their numbers in this assay, from the lowest: compound 2; then compounds 1 and 4 (each within the scatter of the next); then compound 3.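

In this assay, among the compounds shown here, the only step so far at the substituent on the ring nitrogen gives a 6.8-fold lower number from compound 3 to compound 4 (0.83 log units; beyond the scatter) when cyclohexyl replaces methyl, so the outcome at the aromatic carbon depends on more than the choice of a piperazine-type group. The exchange closes only part of the gap to the 2-methylpiperidin-1-yl group, and a 7.4-fold higher number from compound 2 to compound 4 (0.87 log units; beyond the scatter) still lies beyond the scatter. Against benzylamino there is no separation: a 1.4-fold higher number from compound 1 to compound 4 (0.14 log units; within the scatter) lies within the scatter, so 4-cyclohexylpiperazin-1-yl and benzylamino cannot be ranked.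

Going by these compounds, two substituents on that ring nitrogen establish no trend, and where an isopropyl, a benzyl or a 2-hydroxyethyl group would fall relative to them remains open. No evidence at hand accounts for the difference between cyclohexyl and methyl at this nitrogen.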